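Bromo in place of hydrogen on two related cores

The compounds below may be only part of what the source reports. "The series", "measured", "known", "first", "only" and "open" are said of these compounds alone.

The measured compounds:
compound 1 `O=C1NC[C@@H](c2c[nH]c3cc(Br)ccc23)N=C1c1c[nH]c2ccccc12` gives 7.6 ug/mL
compound 2 `O=C1NC[C@@H](c2c[nH]c3ccccc23)N=C1c1c[nH]c2ccccc12` gives 13.7 ug/mL
compound 3 `O=C1NC[C@@H](c2c[nH]c3ccccc23)N[C@H]1c1c[nH]c2ccccc12` gives > 10 ug/mL as a limit of the assay, not a number

All three were tested in an ADME assay on SK-MEL-2 cells (Homo sapiens) for cytotoxicity; on this read-out higher numbers stand for an effect only at larger amounts of compound and lower numbers for an effect already at smaller amounts. Compound 2 and compound 1 share a core and differ in one place, (bromo in place of hydrogen on an aromatic carbon). That change gave a 1.8-fold lower number from compound 2 to compound 1 (0.26 log units; within the scatter), so the two values do not separate from each other.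

For compound 3 only a limit is known, (the limit of > 10 ug/mL in this assay, at which 1 of the 3 values shown sits). The difference between the core of compound 3 and the core of compound 2 is not broken down here.

Compound 4 `O=C1NC[C@@H](c2c[nH]c3ccccc23)N[C@H]1c1c[nH]c2cc(Br)ccc12` has not yet been measured in this assay. Relative to compound 3 it carries the same change, (bromo in place of hydrogen on an aromatic carbon), at a place described in the same words as for the pair of compound 2 and compound 1. Going by the values given here, with only one measured example of this change, and that one within the scatter, the step from compound 3 to compound 4 is expected to be small as well, about a number no higher from compound 3 to compound 4 (the limit leaves the size open), resting on a 1.8-fold lower number from compound 2 to compound 1 (0.26 log units; within the scatter) as the only guide. Since the starting point is a limit rather than a number, the result for compound 4 may again come back as a limit. Compound 4 is therefore estimated at 10 ug/mL, with a range from 5 ug/mL to 25 ug/mL.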

Compound 4, concentration for half-maximal effect: > 10 ug/mL
Compound 4: a limit, no number; the forecaster's own chance of this, stated with the estimate: 40%; the middle value sits exactly at the limit.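

In this assay compound 4 comes back as a limit and not a number, as compound 3 did: the limit of > 10 ug/mL in this assay, at which 2 of the 4 values shown sit. Going by these compounds alone, with both at that limit, no step from compound 3 to compound 4 can be read. The compounds shown leave open whether bromo in place of hydrogen on an aromatic carbon shifts the read-out at all on the core of compound 3.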